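The source may report more compounds than this note shows. Statements on the series, on what has been measured and on what is new or still open speak of the compounds shown alone.

Two compounds of the series have numbers in a functional assay on OVCAR-5 cells (Homo sapiens) for cytotoxicity, read by sulforhodamine B assay, with a stated time of 48 h (on this read-out lower numbers stand for stronger inhibition of growth and higher numbers for weaker inhibition of growth), so far. Compound 1 `ClCc1ccc(Cn2cnc3c(Cl)ncnc32)cc1` gives 9230 nM. Compound 2 `ClCc1ccccc1Cn1cnc2c(Cl)nc(Cl)nc21` gives 2950 nM, the lower of the two numbers; the gap from compound 1 to compound 2 lies beyond the scatter, but these two compounds differ in more than one place, so no single change can be read from it. Compound 3 `ClCc1ccccc1Cn1cnc2c(Cl)ncnc21` is the next compound to be measured in this assay. It differs from compound 2 in one place: hydrogen in place of chloro on an aromatic carbon. Compound 1 also carries hydrogen at this place, yet compound 1 and compound 2 differ in more than this one place, so their two numbers give no clean measure of the change. No firm direction follows from the data; a step from compound 2 to compound 3 of about a 2.0-fold higher number from compound 2 to compound 3 (0.31 log units; beyond the scatter) is expected, a weaker outcome than compound 2 being judged somewhat more likely than a stronger one, with a sizeable chance of no step beyond the scatter. Compound 3 is estimated at 6000 nM, within 2000 nM to 18000 nM.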

Compound 3, concentration for total growth inhibition: 6600 nM
Compound 3: middle estimate off by 1.1-fold (0.04 log units), on the low side, within the range that was stated.
By their numbers in this assay, from the lowest: compound 2; then compounds 3 and 1 (each within the scatter of the next).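

In this assay, the chloro on the aromatic carbon between two ring nitrogen atoms now has a clean one-place measure: hydrogen in its place gives a 2.2-fold higher number from compound 2 to compound 3 (0.35 log units; beyond the scatter), a modest step beyond the scatter. Compound 1 and compound 2 could not show this, as they differ in more than one place; with the rest of the structure held fixed, the chloro at this position goes with the stronger inhibition of growth, and compound 3 with hydrogen there still gives a measured number of 6600 nM. No measurement on these compounds bears on what lies behind the step, so it stands as an observation on one matched pair.

Going by these compounds, only chloro and hydrogen are compared at this position, so it remains open where an amine, a methoxy group or a longer chain there would fall relative to compound 2 and compound 3. It also remains open whether the same change carries over to compound 1, whose counterpart with chloro at this position is not among the compounds shown.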